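This account rests on a few compounds, and the source may have more. Where it says the series, first, only, none or still open, it means among the compounds named here.

In a toxicity assay on HEK-293T cells (Homo sapiens) for cytotoxicity, read by MTT assay, with a stated time of 72 h (a lower number here means a stronger inhibitor, a higher number a weaker inhibitor), compound 1 `CN1CCN(CCCCCCn2c3c(c4ccccc42)C(=O)c2c[n+]([O-])c4ccccc4c2C3=O)CC1` gives 5800 nM. Compound 2 `O=C1c2c[n+]([O-])c3ccccc3c2C(=O)c2[nH]c3ccccc3c21` gives 890 nM. Compound 3 `O=C1c2c[n+]([O-])c3ccccc3c2C(=O)c2c1c1ccccc1n2CCCCN1CCNCC1` gives 760 nM.

Compound 3 shows the lowest of the three numbers, though the step of a 1.2-fold lower number from compound 2 to compound 3 (0.07 log units; within the scatter) stays within the scatter, while a 7.6-fold lower number from compound 1 to compound 3 (0.88 log units; beyond the scatter) lies beyond it. Compound 4 `CN(C)CCCCCn1c2c(c3ccccc31)C(=O)c1c[n+]([O-])c3ccccc3c1C2=O` differs from compound 3 by (dimethylamino)methyl in place of piperazin-1-yl on a saturated chain carbon, four bonds along the chain from an aromatic nitrogen. Going by the values given here, only one measured step alters the tail on that same chain carbon, and it was modest: a 7.6-fold lower number from compound 1 to compound 3 (0.88 log units; beyond the scatter). Among the compounds with values here, the removal of the ring and its donor has no direct precedent here. Compound 4 is therefore expected to shift by a 2.0-fold higher number from compound 3 to compound 4 (0.30 log units; within the scatter), most likely toward a higher number, since the other altered tail on this carbon proved weaker. Compound 4 is estimated at 1500 nM, within a range from 600 nM to 4000 nM.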

Compound 4, half-maximal inhibitory concentration: 70 nM
Estimate against measurement, compound 4: 21-fold (1.33 log units) above, and the stated range ends above it.
By their numbers in this assay, from the lowest: compound 4; then compounds 3 and 2 (each within the scatter of the next); then compound 1.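

In this assay the tail on this saturated chain carbon can lower the number sharply, as shown by an 11-fold lower number from compound 3 to compound 4 (1.04 log units; beyond the scatter), far more than the earlier step to a piperazin-1-yl tail suggested. The 5-(dimethylamino)pentyl group on the aromatic nitrogen also separates itself from hydrogen, with a 13-fold lower number from compound 2 to compound 4 (1.10 log units; beyond the scatter), whereas the 4-(piperazin-1-yl)butyl group did not, and the widest gap is an 83-fold lower number from compound 1 to compound 4 (1.92 log units; beyond the scatter). Nothing available explains this difference.

The compounds shown leave open whether the dimethylamino end or the chain length carries the change. A 4-(dimethylamino)butyl chain, or a pyrrolidin-1-yl end on the pentyl chain, would help separate the two.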